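Replacing 4-chlorobutyl with 3-bromoprop-1-en-1-yl on a carbonyl carbon

The compounds below may be only part of what the source reports. "The series", "measured", "known", "first", "only" and "open" are said of these compounds alone.

In a functional assay on MGC-803 cells (Homo sapiens) for inhibition, read by MTT assay, with a stated time of 48 h (on this read-out lower numbers stand for stronger inhibition and higher numbers for weaker inhibition), compound 1 `COc1ccc(CN(C(=O)CCl)c2cc(OC)c(OC)c(OC)c2)cc1O` gives 84 nM. Compound 2 `COc1ccc(CN(C(=O)CCCCCl)c2cc(OC)c(OC)c(OC)c2)cc1O` gives 540 nM, the higher of the two numbers. The next compound to be tested is compound 3 `COc1ccc(CN(C(=O)/C=C/CBr)c2cc(OC)c(OC)c(OC)c2)cc1O`, which differs from compound 2 on the carbonyl carbon: 3-bromoprop-1-en-1-yl in place of 4-chlorobutyl on a carbonyl carbon. Among the compounds with values here, only one measured step bears on this place, and it is modest but beyond the scatter: a 6.4-fold higher number from compound 1 to compound 2 (0.81 log units; beyond the scatter). Neither measured compound carries bromine or a double bond in this chain, so that step is only a loose guide. In this assay, a move away from the 4-chlorobutyl group of compound 2 is expected to give a lower number, of a size similar to or somewhat smaller than the measured step. The expected change is a 4.5-fold lower number from compound 2 to compound 3 (0.65 log units; beyond the scatter). For compound 3 the estimated value is 120 nM, within an expected range of 25 nM to 600 nM.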

Compound 3, half-maximal inhibitory concentration: 71 nM
The estimate for compound 3 lay 1.7-fold (0.23 log units) above the measured number; the measured number falls inside the stated range.
By their numbers in this assay, from the lowest: compounds 3 and 1 (each within the scatter of the next); then compound 2.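

In this assay, the long 4-chlorobutyl chain of compound 2 is not the only alternative to chloromethyl at this carbonyl carbon that matters: a shorter unsaturated chain ending in bromine restores the lower numbers, with a 7.6-fold lower number from compound 2 to compound 3 (0.88 log units; beyond the scatter). A low number at this place is therefore not confined to chloromethyl, since the two groups cannot be told apart, with a 1.2-fold lower number from compound 1 to compound 3 (0.07 log units; within the scatter). No measurement shown accounts for these differences.

The double bond, the bromine and the shorter chain all enter together in compound 3, so the compounds shown do not say which of them goes with the lower number. A saturated 3-bromopropyl chain, a 3-chloroprop-1-en-1-yl group or an amine in place of the halogen would each bear on that question.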